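Changing the aryl group on the amide-type nitrogen

This account rests on a few compounds, and the source may have more. Where it says the series, first, only, none or still open, it means among the compounds named here.

Compound 1 `O=C(Nc1ccc(Br)cc1)N[C@H]1CC[C@H](Oc2ccc(F)cc2)CC1`: > 20000 nM
Compound 2 `COc1ccc(NC(=O)N[C@H]2CC[C@H](Oc3ccc(F)cc3)CC2)cc1`: > 20000 nM
Compound 3 `COc1cccc(NC(=O)N[C@H]2CC[C@H](Oc3ccc(F)cc3)CC2)c1`: 14000 nM

In a functional assay on CRL2813 cells (Homo sapiens) for cytotoxicity, read by sulforhodamine B assay, with a stated time of 5 days (a lower number here means a stronger inhibitor, a higher number a weaker inhibitor), compound 3 is the only one of the three with a number, giving 14000 nM. Compound 1 reaches only a limit of the assay, > 20000 nM. Compound 2 likewise reaches only a limit, > 20000 nM. Compound 4 `O=C(Nc1ccc(F)cc1)N[C@H]1CC[C@H](Oc2ccc(F)cc2)CC1` differs from compound 3 by 4-fluorophenyl in place of 3-methoxyphenyl on an amide-type nitrogen. Among the measured compounds shown here, the steps that bear on this are an at least 1.4-fold lower number from compound 2 to compound 3 (0.15 log units; that floor lies within the scatter) and an at least 1.4-fold lower number from compound 1 to compound 3 (0.15 log units; that floor lies within the scatter); both go from a 4-substituted phenyl to 3-methoxyphenyl, and compound 4 reverses that pattern. A higher number is therefore expected, quite possibly again at the limit of > 20000 nM in this assay, at which 2 of the 3 values shown sit. Compound 4 is estimated at 25000 nM, between 8000 nM and 60000 nM. The expected step is a 1.8-fold higher number from compound 3 to compound 4 (0.25 log units; within the scatter).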

Compound 4, half-maximal inhibitory concentration: 20000 nM
For compound 4 the middle estimate is 1.3-fold (0.10 log units) above the measured one; low and high end bracket the measured number.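

In this assay, compound 4 with its 4-fluorophenyl group gives a readable number, so a group of this kind on the amide-type nitrogen need not end at a limit, and the step is a 1.4-fold higher number from compound 3 to compound 4 (0.15 log units; within the scatter). That step does not separate 4-fluorophenyl from 3-methoxyphenyl at this position. The two further steps are a number no higher from compound 2 to compound 4 (the limit leaves the size open) and a number no higher from compound 1 to compound 4 (the limit leaves the size open); their size cannot be read, and one limit governs both: the limit of > 20000 nM in this assay, at which 2 of the 4 values shown sit.

As far as these compounds go, whether any group here moves the number beyond the scatter stays open. A phenyl ring carrying an amine or a carboxylic acid would test this.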